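Aryl acid swap on the cyclopentylmethyl ketone series

The source may report more compounds than this note shows. Statements on the series, on what has been measured and on what is new or still open speak of the compounds shown alone.

Notes on three compounds measured in an assay on HEK293 cells for positive allosteric modulation of metabotropic glutamate receptor 3 (Rattus norvegicus), read by thallium flux, with a stated time of 2.5 min; on this read-out lower numbers stand for smaller maximal responses and higher numbers for larger maximal responses: compound 1 `CCCC(=O)c1ccc(OCCCCOc2ccc(F)c(C(=O)O)c2)c(C)c1O` gives 56.9%, compound 2 `COc1ccc(C(=O)O)cc1OCCCCOc1ccc(C(=O)CC2CCCC2)c(O)c1C` gives 67.6%, and compound 3 `COc1ccc(C(=O)O)cc1OCCCCOc1ccc(C(=O)CC(C)C)c(O)c1C` gives 100%. Compound 2 stands second highest of the three, with compound 1 lower and compound 3 higher, both gaps beyond the scatter. Within the data shown here, the one single-site step known is a number 32.4 percentage points higher from compound 2 to compound 3 (beyond the scatter), which concerns the group on the saturated chain carbon bound to the carbonyl carbon, not the aryl acid.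

Compound 4 `Cc1c(OCCCCOc2ccc(F)c(C(=O)O)c2)ccc(C(=O)CC2CCCC2)c1O` is unmeasured. It differs from compound 2 by 3-carboxy-4-fluorophenyl in place of 5-carboxy-2-methoxyphenyl on an oxygen on a saturated carbon. Among the measured compounds shown here, no measured step concerns this change alone; compound 1 carries the same 3-carboxy-4-fluorophenyl piece but also a different ketone chain, so its value of 56.9% is only indirect guidance, sitting below compound 2.

The step from compound 2 to compound 4 is therefore expected to be small or modestly downward, a number 7.6 percentage points lower from compound 2 to compound 4 (within the scatter), with wide uncertainty. Compound 4 is estimated at 60%, in the range 40% to 85%.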

Compound 4, largest response reached (reported as percent of maximum), in percent of the reference or control that the assay uses: 98.4%
The estimate for compound 4 lay 38.4 percentage points below the measured number; the measured number lies above the stated range.
By their numbers in this assay, from the lowest: compound 1; then compound 2; then compounds 4 and 3 (each within the scatter of the next).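

In this assay, among these compounds, 3-carboxy-4-fluorophenyl in place of 5-carboxy-2-methoxyphenyl on an oxygen on a saturated carbon gives a number 30.8 percentage points higher from compound 2 to compound 4 (beyond the scatter), the first direct evidence that the aryl acid piece alone can shift the maximal response in the cyclopentyl ketone series. With that piece held constant, cyclopentyl in place of ethyl on a saturated chain carbon bound to a carbonyl carbon gives a number 41.5 percentage points higher from compound 1 to compound 4 (beyond the scatter), so the ketone chain also matters on this aryl acid. Nothing in hand bears on the reason for either step.

Going by these compounds, whether the aryl acid step carries over to the isopropyl ketone chain of compound 3 remains open. Also open, on these data alone, is whether the fluorine itself contributes to the step, and how chlorine or a tetrazole in the same piece would read out.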